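Swapping an Aryl Amine for an Indolylethyl Thioether

A few compounds are considered here, and "the series" means these few. Any claim that something is new, unique, unknown or untested is made for them only; others in the source may bear on it.

Compound 2 `COc1cc(CNC(=O)CCCC/C=C/C(C)C)ccc1OCc1nnc(Nc2ccccc2F)o1` gives 10500 nM in a functional assay on HCT-116 cells (Homo sapiens) for inhibition, read by crystal violet staining, with a stated time of 72 h (on this read-out higher numbers stand for weaker inhibition and lower numbers for stronger inhibition), and compound 1 `COc1cc(CNC(=O)CCCC/C=C/C(C)C)ccc1OCc1nnc(Nc2ccc([N+](=O)[O-])cc2)o1` gives 8550 nM, the two lying within the scatter of each other, as a 1.2-fold higher number from compound 1 to compound 2 (0.09 log units; within the scatter) shows. Compound 3 `COc1cc(CNC(=O)CCCC/C=C/C(C)C)ccc1OCc1nnc(SCCc2c[nH]c3ccccc23)o1` changes the substituent on the five-membered ring: (2-(1H-indol-3-yl)ethyl)sulfanyl in place of (2-fluorophenyl)amino on an aromatic carbon. Going by the values given here, no measured step touches this position with a comparable group; the only step available, a 1.2-fold higher number from compound 1 to compound 2 (0.09 log units; within the scatter), stayed within the scatter. Compound 3 is therefore expected to show no step beyond the scatter, a 1.2-fold lower number from compound 2 to compound 3 (0.07 log units; within the scatter), with considerable uncertainty. Compound 3 is estimated at 9000 nM, between 2500 nM and 32000 nM.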

Compound 3, half-maximal inhibitory concentration: 13400 nM
Beside the measured number, compound 3's estimate is 1.5-fold (0.17 log units) below it, within the range that was stated.
By their numbers in this assay, from the lowest: compounds 1, 2 and 3 (each within the scatter of the next).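

Earlier, only the aryl group on the amino link had varied; here the link and the aryl group both change, and this assay gives a 1.3-fold higher number from compound 2 to compound 3 (0.11 log units; within the scatter) and a 1.6-fold higher number from compound 1 to compound 3 (0.20 log units; within the scatter). Even with 12 heavy atoms in place of 8, and sulfur in place of the amino nitrogen, this position leaves the number within the scatter across all three compounds. Nothing available explains why the change has so little effect. From the compounds shown here alone, whether a carboxylic acid or a simple amine at this position would move the number stays open, as does whether any substituent here matters in this assay.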